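This account rests on a few compounds, and the source may have more. Where it says the series, first, only, none or still open, it means among the compounds named here.

Measured compounds:
Compound 1, `O=C(Nc1nc2ccc(F)cc2s1)N1CCN(c2ccc(Cl)nn2)CC1`: in an assay on HEK293 cells for inhibition of transient receptor potential cation channel subfamily V member 1 (Homo sapiens), read by FLIPR, at pH 5.5 (on this read-out lower numbers stand for stronger inhibition and higher numbers for weaker inhibition), compound 1 gives > 10000 nM, which is a limit of the assay and not a number.
Compound 2, `O=C(Nc1nc2ccc(F)cc2s1)N1CCN(c2cccnn2)CC1`: in this assay compound 2 gives > 10000 nM, again a limit of the assay.
Compound 3, `Cc1ccnnc1N1CCN(C(=O)Nc2ccc(C(C)(C)C)cc2)[C@H](C)C1`: in this assay compound 3 gives 15.2 nM.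

Compound 3 is the only one of the three with a number; the other two values are limits, as the line the limit of > 10000 nM in this assay, at which 2 of the 3 values shown sit, records. How the core of compound 3 differs from the core of compound 2 is not broken down here.

Compound 4, `Cc1cc(Cl)nnc1N1CCN(C(=O)Nc2ccc(C(C)(C)C)cc2)[C@H](C)C1`, has not yet been measured in this assay. It comes from compound 3 by chloro in place of hydrogen on an aromatic carbon. The change from compound 2 to compound 1 is chloro in place of hydrogen on an aromatic carbon, the same kind of change, not the same: in compound 4 the place is also meta to a methyl group (1 heavy atom), while in compound 1 it is not. The measured step that the two limits leave unreadable from compound 2 to compound 1 cannot tell the size of this change, since both values sit at a limit.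

With no readable step to rest on, the expectation for compound 4 leans on the value of compound 3 alone, and the step of a 1.0-fold lower number from compound 3 to compound 4 (0.01 log units; within the scatter) is estimated to be small. Compound 4 is expected to give about 15 nM in this assay, with a range of 5 nM to 50 nM allowed for.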

Compound 4, half-maximal inhibitory concentration: 67.5 nM
Compound 4: middle estimate off by 4.5-fold (0.65 log units), on the low side, and the stated range ends below it.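

In this assay, putting chloro in place of hydrogen on an aromatic carbon, which turns 4-methylpyridazin-3-yl into 6-chloro-4-methylpyridazin-3-yl, gives a 4.4-fold higher number from compound 3 to compound 4 (0.65 log units; beyond the scatter), so on this core the change weakens inhibition without abolishing it. The same kind of change on the other core, the pair of compound 2 and compound 1, cannot be read, because both of its values are limits of the assay and not numbers: the limit of > 10000 nM in this assay, at which 2 of the 4 values shown sit. What remains is one readable step on one core, which shows what the change did in this pair but not whether it would have the same direction or size on the core of compound 2, so nothing can yet be said about it carrying from one core to another.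

On these data alone, at this place on the ring only hydrogen and chloro can be compared, so it remains open whether fluoro, a methoxy group or an amine would be tolerated better or worse than chloro. As far as these compounds go, it is also open whether chloro would give a similar step in a compound without the methyl group on that ring, since the methyl group is present in both compound 3 and compound 4.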